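The compounds below may be only part of what the source reports. "The series", "measured", "known", "first", "only" and "open" are said of these compounds alone.

Measured so far in a functional assay on MCF-10A cells (Homo sapiens) for antiproliferative activity, with a stated time of 48 h; on this read-out higher numbers stand for an effect only at larger amounts of compound and lower numbers for an effect already at smaller amounts:
- compound 1, `COc1ccc2nc(C)cc(NCc3cccc(F)c3)c2c1`: compound 1 gives 11300 nM
- compound 2, `COc1ccc2nc(C)cc(NCc3ccc(OC)c(F)c3)c2c1`: compound 2 gives 9000 nM
- compound 3, `Cc1cc(NCc2ccc(F)cc2)c2ccccc2n1`: compound 3 gives 15400 nM

Compounds 1 and 2 share one core; compound 3 rests on another, and the difference between the two cores is not broken down here. All three values sit within the scatter of one another, so no order among them can be read from these numbers.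

The change from compound 1 to compound 2 is methoxy in place of hydrogen on an aromatic carbon, and it gave a 1.3-fold lower number from compound 1 to compound 2 (0.10 log units; within the scatter). Compound 4, `COc1ccc2c(NCc3ccc(F)cc3)cc(C)nc2c1`, is still to be measured in this assay. It arises from compound 3 by methoxy in place of hydrogen on an aromatic carbon. Going by the values given here, this is the same kind of change as the one from compound 1 to compound 2, not the same: in compound 2 the methoxy sits ortho to a fluoro group and para to a large group, whereas in compound 4 it sits on a ring that is part of a fused system, meta to a fused ring and para to a fused ring.

From compound 3 to compound 4 a step of about a 1.3-fold lower number from compound 3 to compound 4 (0.11 log units; within the scatter) is expected, set beside the step from compound 1 to compound 2, because the measured 1.3-fold lower number from compound 1 to compound 2 (0.10 log units; within the scatter) was small; the different surroundings of the new group leave this expectation loose. For compound 4 the estimate is 12000 nM, between 6000 nM and 24000 nM.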

Compound 4, half-maximal effective concentration: 10200 nM
Estimate against measurement, compound 4: 1.2-fold (0.07 log units) above; low and high end bracket the measured number.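

In this assay, methoxy in place of hydrogen on an aromatic carbon gave a 1.5-fold lower number from compound 3 to compound 4 (0.18 log units; within the scatter), so this step, like the earlier one, is small. Within what this read-out can resolve, the change carries over from one core to the other without a detectable difference: the same change on two cores in this assay, a 1.3-fold lower number (0.10 log units; within the scatter) from compound 1 to compound 2 and a 1.5-fold lower number (0.18 log units; within the scatter) from compound 3 to compound 4, 1.2-fold (0.08 log units) apart, within the scatter of two such steps

Going by these compounds alone, this does not show that methoxy lowers the number on either core, since each step lies within the scatter; the agreement rests on only two pairs of compounds, with the new group in different surroundings in each pair, and so establishes no general rule for the series.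

Still open, on these data alone, is whether an amine, a carboxylic acid or a longer chain in place of methoxy on the same aromatic carbon would move the number beyond the scatter. Also open, as far as these compounds go, is whether the small methoxy step would hold on a third core.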